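A few compounds are considered here, and "the series" means these few. Any claim that something is new, unique, unknown or untested is made for them only; others in the source may bear on it.

Three compounds have been measured in a functional assay on A549 cells (Homo sapiens) for cytotoxicity, read by MTT assay, with a stated time of 48 h; on this read-out higher numbers stand for weaker inhibition and lower numbers for stronger inhibition:

Compound 1, `COc1ccc(-c2cc(C(=O)Nc3nc4ccc(F)cc4s3)nc3cc(-c4ccccc4)nn23)cc1OC`, gives 6910 nM.
Compound 2, `COc1ccc2nc(NC(=O)c3cc(-c4ccc(OC)c(OC)c4)n4nc(-c5ccccc5)cc4n3)sc2c1`, gives 15800 nM.
Compound 3, `Cc1cc2nc(NC(=O)c3cc(-c4ccc(F)cc4)n4nc(-c5ccccc5)cc4n3)sc2cc1C`, gives 12600 nM.

Compound 1 and compound 2 share one core and differ in a single place: methoxy in place of fluoro on an aromatic carbon. That change made a 2.3-fold higher number from compound 1 to compound 2 (0.36 log units; beyond the scatter). Compound 3 is built on a different core, and the difference between the two cores is not broken down here. The values of compound 2 and compound 3 lie close together, and both sit near that of compound 1.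

Compound 4, `COc1ccc(-c2cc(C(=O)Nc3nc4cc(C)c(C)cc4s3)nc3cc(-c4ccccc4)nn23)cc1`, has not yet been measured in this assay. It differs from compound 3 in one place: methoxy in place of fluoro on an aromatic carbon. Among the compounds with values here, this is the same kind of change as the one from compound 1 to compound 2, but not the same change. In the earlier pair the altered carbon belongs to a ring that is part of a fused or bridged system of two rings, meta to a fused ring and para to a fused ring; in compound 4 it belongs to a six-membered aromatic ring of carbon only, para to a large group.

The step expected from compound 3 to compound 4 in this assay is estimated as a 1.6-fold higher number from compound 3 to compound 4 (0.20 log units; within the scatter), beside the earlier step. This rests on the measured step of a 2.3-fold higher number from compound 1 to compound 2 (0.36 log units; beyond the scatter) for the same kind of change, tempered by the different surroundings of the changed carbon, starting from the value of compound 3, 12600 nM. The value expected for compound 4 is therefore 20000 nM, estimated to fall between 8000 nM and 50000 nM.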

Compound 4, half-maximal inhibitory concentration: 13200 nM
Estimate against measurement, compound 4: 1.5-fold (0.18 log units) above, within the range that was stated.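

Within the data shown here, replacing fluoro with methoxy on an aromatic carbon, which turns the 4-fluorophenyl group into a 4-methoxyphenyl group, gave a 1.0-fold higher number from compound 3 to compound 4 (0.02 log units; within the scatter) in this assay, so on this core the swap produced no step that stands out from the ordinary variation between repeated measurements. The earlier step on the other core was beyond the scatter and this one is within it, yet the two steps themselves cannot be told apart: the same change on two cores in this assay, a 2.3-fold higher number (0.36 log units; beyond the scatter) from compound 1 to compound 2 and a 1.0-fold higher number (0.02 log units; within the scatter) from compound 3 to compound 4, 2.2-fold (0.34 log units) apart, within the scatter of two such steps. The data therefore show no real difference in how the change behaves on the two cores, but they do not prove that it carries over unchanged, since two pairs are few and the changed carbon lies in a ring fused to another in one pair and on a six-membered aromatic ring of carbon only, para to a large group, in the other, so core and surroundings cannot be separated.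

The compounds shown leave open how the same swap would behave on a third core, or at another carbon of the same ring. They also leave open what a different group at the changed carbon, such as an amine, a carboxylic acid or a longer chain like butoxy, would do to the number in this assay.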